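Dibromo-Hydroxyphenyl Hydrazone Tested on Colon Cancer Cells

This account rests on a few compounds, and the source may have more. Where it says the series, first, only, none or still open, it means among the compounds named here.

Measured so far:
Compound 1, `O=C(CSc1nnc(-c2ccncc2)o1)N/N=C/c1ccc(F)cc1`, gives 15700 nM in a functional assay on SW 1116 cells (Homo sapiens) for cytotoxicity, read by MTT assay, with a stated time of 48 h; on this read-out lower numbers stand for stronger inhibition and higher numbers for weaker inhibition.
Compound 2, `O=C(CSc1nnc(-c2ccncc2)o1)N/N=C/c1cccc(F)c1`, gives 26700 nM in this assay.
Compound 3, `O=C(CSc1nnc(-c2ccncc2)o1)N/N=C/c1ccccc1O`, gives 7380 nM in this assay.

All three share the same core and differ only in the aromatic ring attached to the carbon with a double bond to nitrogen. Among the three numbers, compound 1 stands second highest. Its nearest neighbour is compound 2, a 1.7-fold higher number from compound 1 to compound 2 (0.23 log units; within the scatter), a gap that means nothing here. The furthest is compound 3, a 2.1-fold lower number from compound 1 to compound 3 (0.33 log units; beyond the scatter), a modest but real step.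

Compound 4, `O=C(CSc1nnc(-c2ccncc2)o1)N/N=C/c1cc(Br)cc(Br)c1O`, differs from compound 1 in a single place: 3,5-dibromo-2-hydroxyphenyl in place of 4-fluorophenyl on a carbon with a double bond to nitrogen. The measured step that bears on this change is the one introducing 2-hydroxyphenyl, a 2.1-fold lower number from compound 1 to compound 3 (0.33 log units; beyond the scatter), and the step of a 3.6-fold lower number from compound 2 to compound 3 (0.56 log units; beyond the scatter) points the same way. For the measured compounds named here, nothing measured so far shows what the two bromine atoms contribute, so that part of the change stays open and widens the range.

On this basis a modest step to a lower number in this assay is expected, roughly like that from compound 1 to compound 3. Compound 4 is therefore estimated at 5000 nM, with a range from 1500 nM to 16000 nM, which means an expected step of a 3.1-fold lower number from compound 1 to compound 4 (0.50 log units; beyond the scatter).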

Compound 4, half-maximal inhibitory concentration: 8570 nM
Compound 4: middle estimate off by 1.7-fold (0.23 log units), on the low side; low and high end bracket the measured number.
By their numbers in this assay, from the lowest: compounds 3, 4, 1 and 2 (each within the scatter of the next, the first and the last beyond it).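

The two bromine atoms of compound 4 make no readable difference in this assay when the group with them is set against plain 2-hydroxyphenyl (a 1.2-fold higher number from compound 3 to compound 4 (0.06 log units; within the scatter)), so this position takes the heavier 3,5-dibromo-2-hydroxyphenyl group with neither gain nor loss that can be told from the scatter. Compound 4 also cannot be separated from compound 1 (a 1.8-fold lower number from compound 1 to compound 4 (0.26 log units; within the scatter)), and only the comparison with the 3-fluorophenyl group of compound 2 clears the scatter (a 3.1-fold lower number from compound 2 to compound 4 (0.49 log units; beyond the scatter)), so the new group adds a second compound that lies clear of compound 2 without setting a new level of its own. Nothing at hand explains why these numbers fall as they do.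

With a single bromine, the share of each of the two bromine atoms could be told apart, but the compounds shown include no such group. As far as these compounds go, whether a methoxy group, an amine or a carboxylic acid on the phenyl ring at this same carbon would move the number clearly away from that of compound 3 also remains open.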